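An Oxetane Exchanged for Isopropoxy on a Sulfonamide Core

A few compounds are considered here, and "the series" means these few. Any claim that something is new, unique, unknown or untested is made for them only; others in the source may bear on it.

Compound 1 `C[C@@H](c1ccc(Cl)cc1)N1Cc2cncn2C(CC2(C)COC2)S1(=O)=O` was tested in an assay on cells for inhibition of cytochrome P450 11B2, mitochondrial (Homo sapiens) (a lower number here means a stronger inhibitor, a higher number a weaker inhibitor), where compound 1 gives 7.8 nM. For the measured compounds named here, the only other compound measured so far, compound 2 `CC(C)CC1n2cncc2CN(Cc2ccccc2)S1(=O)=O`, gives in this assay a value of 18.6 nM. Of these two numbers, compound 1 holds the lower one, and the gap between them lies beyond the usual scatter of repeated measurements; the two compounds differ in more than one place, so the gap cannot be tied to any single change. Compound 3 `CC(C)OCC1n2cncc2CN([C@@H](C)c2ccc(Cl)cc2)S1(=O)=O` has not yet been measured. It differs from compound 1 by isopropoxy in place of 3-methyloxetan-3-yl on a saturated chain carbon bound to a saturated ring carbon. Going by the values given here, no measured pair shows this particular change, so the expectation rests on compound 1 alone. The step of a 1.3-fold higher number from compound 1 to compound 3 (0.11 log units; within the scatter) is expected to be small, with no clear direction, and likely within the scatter. Compound 3 is therefore expected to give in this assay about 10 nM, with a range from 3 nM to 35 nM.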

Compound 3, half-maximal inhibitory concentration: 0.8 nM
The estimate for compound 3 lay 13-fold (1.10 log units) above the measured number, and the stated range ends above it.
By their numbers in this assay, from the lowest: compound 3; then compound 1; then compound 2.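

For the compounds shown here, exchanging (3-methyloxetan-3-yl)methyl for isopropoxymethyl, with the rest of compound 1 unchanged, gives a 9.8-fold lower number from compound 1 to compound 3 (0.99 log units; beyond the scatter) in this assay and is the first single change that can be read. It shows that this place, on a saturated chain carbon bound to a saturated ring carbon, is sensitive to the group it carries, even though the leaving and entering groups each count one hydrogen-bond acceptor and no donors. The data offered here give no measured basis for explaining this step.

Going by these compounds, whether the lower number follows from the open chain or from the particular shape of isopropoxy remains open. The compounds shown include no ethoxy, cyclopropoxy or amine at this place on the core of compound 1, so how far the trend extends cannot be said.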